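Sulfur for Oxygen on the Benzyl Ring of Two Cores

The source may report more compounds than this note shows. Statements on the series, on what has been measured and on what is new or still open speak of the compounds shown alone.

Compound 1 `CSc1ccc(CNc2nc(SC)nc3ncccc23)cc1` and compound 2 `COc1ccc(CNc2nc(SC)nc3ncccc23)cc1` share one core and differ only at the benzyl ring. In an ADME assay on 184B5 cells (Homo sapiens) for cytotoxicity, read by MTT assay, with a stated time of 72 h (a higher number here means a weaker inhibitor of growth, a lower number a stronger inhibitor of growth), compound 1 gives 190 nM, while compound 2 gives 34200 nM. The step of a 180-fold lower number from compound 2 to compound 1 (2.26 log units; beyond the scatter) comes from methylsulfanyl in place of methoxy on an aromatic carbon. Compound 3 `COc1ccc(CNc2nc(SC)nc3ccccc23)cc1` carries the same methoxy group on a second core; in this assay compound 3 gives 85600 nM, the highest of the three numbers. The difference between the two cores is not broken down here. Compound 4 `CSc1ccc(CNc2nc(SC)nc3ccccc23)cc1` is the partner of compound 3 in which the same change is made, (methylsulfanyl in place of methoxy on an aromatic carbon), with the same kind of wording for its place as in the earlier pair. Because the earlier step of a 180-fold lower number from compound 2 to compound 1 (2.26 log units; beyond the scatter) was large and the two cores differ only modestly in their methoxy members, it is expected that compound 4 will fall well below compound 3, by roughly a 170-fold lower number from compound 3 to compound 4 (2.23 log units; beyond the scatter) in this assay. The estimated value for compound 4 is therefore 500 nM, expected to lie between 100 nM and 2500 nM.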

Compound 4, concentration for 50% growth inhibition: 22000 nM
Compound 4: the middle estimate sits 44-fold (1.64 log units) below what was measured, and the stated range ends below it.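

In this assay, methylsulfanyl in place of methoxy on the core of compound 3 gives a 3.9-fold lower number from compound 3 to compound 4 (0.59 log units; beyond the scatter), so the direction of the change is the same on both cores shown. The size of the step does not carry over from one core to the other: the same change on two cores in this assay, a 180-fold lower number (2.26 log units; beyond the scatter) from compound 2 to compound 1 and a 3.9-fold lower number (0.59 log units; beyond the scatter) from compound 3 to compound 4, 46-fold (1.67 log units) apart, beyond the scatter of two such steps. These two pairs show that the core can strongly alter what this one change does, but they do not show which feature of the core is responsible, nor what size the step would take on any further core.

The compounds shown leave open whether the same dependence on the core would appear with other groups in place of methoxy on the benzyl ring, such as an ethoxy group, a chlorine atom or a dimethylamino group. They also leave open how either core would respond if the methylsulfanyl group that all four compounds carry on the core were replaced by an amine or a longer chain.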